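Methyl for chloro on the pyrrolidinylmethyl-bearing core

This account rests on a few compounds, and the source may have more. Where it says the series, first, only, none or still open, it means among the compounds named here.

Measured so far in a physicochemical assay for lipophilicity, at pH 7.4; a lower number here means a more polar compound, a higher number a more lipophilic compound:
compound 1, `Clc1ccc(-c2c[nH]c(CNc3ccnc4cc(Cl)ccc34)n2)cc1`, gives 5.34
compound 2, `Cc1ccc(-c2c[nH]c(CNc3ccnc4cc(Cl)ccc34)n2)cc1`, gives 4.95
compound 3, `Clc1ccc(-c2nc(CNc3ccnc4cc(Cl)ccc34)[nH]c2CN2CCCC2)cc1`, gives 6.96

Compound 2 differs from compound 1 by methyl in place of chloro on an aromatic carbon, and this step reads a number 0.39 log units lower from compound 1 to compound 2 (beyond the scatter). Compound 3 differs from compound 1 by (pyrrolidin-1-yl)methyl in place of hydrogen on an aromatic carbon, a step of a number 1.62 log units higher from compound 1 to compound 3 (beyond the scatter), which leaves compound 3 with the highest value of the three.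

Compound 4, `Cc1ccc(-c2nc(CNc3ccnc4cc(Cl)ccc34)[nH]c2CN2CCCC2)cc1`, has not yet been measured. It differs from compound 3 by methyl in place of chloro on an aromatic carbon, the same change that takes compound 1 to compound 2; the place of the change is described in the same words in both pairs, so it is taken as the same change on a different core. For compound 4 a step of a number 0.39 log units lower from compound 3 to compound 4 (beyond the scatter) is expected, resting on the step of a number 0.39 log units lower from compound 1 to compound 2 (beyond the scatter) seen on the core of compound 1. Compound 4 is therefore estimated at 6.57, with the expected range from 6.2 to 6.95.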

Compound 4, partition coefficient: 6.45
Estimate against measurement, compound 4: 0.12 log units above; the measured number falls inside the stated range.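

In this assay the change from 4-chlorophenyl to 4-methylphenyl gives a number 0.51 log units lower from compound 3 to compound 4 (beyond the scatter) on the core carrying the (pyrrolidin-1-yl)methyl group and a number 0.39 log units lower from compound 1 to compound 2 (beyond the scatter) on the core of compound 1 without that group, so the change keeps its direction on both cores. Read the other way, the (pyrrolidin-1-yl)methyl group gives a number 1.50 log units higher from compound 2 to compound 4 (beyond the scatter) with the 4-methylphenyl and a number 1.62 log units higher from compound 1 to compound 3 (beyond the scatter) with the 4-chlorophenyl, again in one direction. For the compounds shown here, these are only two pairs on two cores, which does not establish that the change carries to any other core, and no measurement is at hand to explain the size of either step.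

Still open, going by these compounds, is whether the same direction holds for other groups in place of chloro on that aromatic carbon, such as methoxy or trifluoromethyl. Also open, on these data alone, is whether another amine in place of pyrrolidine, such as morpholine or dimethylamine, gives a step of similar size.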